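1-Bromonaphthalen-2-yl to 3-chlorophenyl on the shared core

The source may report more compounds than this note shows. Statements on the series, on what has been measured and on what is new or still open speak of the compounds shown alone.

In a functional assay on A549 cells (Homo sapiens) for antiproliferative activity, with a stated time of 5 days (a lower number here means a stronger inhibitor, a higher number a weaker inhibitor), compound 1 `O=C1C=CC2(C=C1)OCC(=O)N2c1nc(-c2ccc3ccccc3c2Br)nn1-c1ccccc1` gives 100 nM and compound 2 `Cc1ccc(-n2nc(-c3cccc4ccccc34)nc2N2C(=O)COC23C=CC(=O)C=C3)cc1` gives 140 nM, two values within the scatter of each other. Compound 3 `O=C1C=CC2(C=C1)OCC(=O)N2c1nc(-c2ccc3ccccc3c2)nn1-c1ccc(Cl)cc1` gives 400 nM, a higher number than compound 1 by more than the scatter. Compound 1 therefore sits at the low end of the numbers shown, level with compound 2.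

Compound 4 `O=C1C=CC2(C=C1)OCC(=O)N2c1nc(-c2cccc(Cl)c2)nn1-c1ccccc1` has not yet been measured. It keeps the shared core and the phenyl group of compound 1, with 3-chlorophenyl in place of 1-bromonaphthalen-2-yl on an aromatic carbon. For the measured compounds named here, no measured pair isolates this change, and none of the three measured compounds has a single aromatic ring at that carbon, so the expectation goes beyond the measured range of structures. Going by the values given here, the only guide to size is the gap between compound 1 at 100 nM and compound 3 at 400 nM, and a move of similar size is assumed. The step expected is a 4.0-fold higher number from compound 1 to compound 4 (0.60 log units; beyond the scatter), a rise in the number beyond the scatter. In this assay the estimate for compound 4 is 400 nM, with an expected range of 120 nM to 1500 nM.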

Compound 4, half-maximal inhibitory concentration: 25.2 nM
Compound 4: the middle estimate sits 16-fold (1.20 log units) above what was measured; measured number below the stated range.
By their numbers in this assay, from the lowest: compound 4; then compounds 1 and 2 (each within the scatter of the next); then compound 3.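

In this assay, the aromatic carbon between two ring nitrogen atoms does not require 1-bromonaphthalen-2-yl: 3-chlorophenyl, with one six-membered aromatic ring of carbon only, gives a 4.0-fold lower number from compound 1 to compound 4 (0.60 log units; beyond the scatter). For the compounds shown here, the earlier compounds all carried two six-membered aromatic rings at this carbon, so this is the first reading of a single ring there, and it shows that the second ring can be lost here with no loss of activity in this cell assay. No supporting measurement bears on why the number falls with this change, so the step stands as an observation only.

This one change removes a ring, replaces bromine with chlorine and moves the halogen together, so the compounds shown do not separate these contributions to the step. Also open, on these data alone, is whether a nitrile, a methoxy group or an amine can take the place of the chlorine on the single ring, and whether the step holds with a group other than phenyl on the ring nitrogen.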